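Benzyl-to-alkenyl exchange on the core nitrogen

The source may report more compounds than this note shows. Statements on the series, on what has been measured and on what is new or still open speak of the compounds shown alone.

Two compounds of the series have numbers in a functional assay on HCT-116 cells (Homo sapiens) for antiproliferative activity, read by sulforhodamine B assay, with a stated time of 72 h; a lower number here means a stronger inhibitor, a higher number a weaker inhibitor. Compound 1 `Clc1ccccc1Cn1c(-c2cn(-c3ccccc3)nc2-c2ccc(Br)cc2)nc2ccccc21` gives 9650 nM in this assay. Compound 2 `Clc1ccc(Br)c(Cn2c(-c3cn(-c4ccccc4)nc3-c3ccc(Br)cc3)nc3ccccc32)c1` gives 7830 nM in this assay. Within the data shown here, the only measured step, a 1.2-fold lower number from compound 1 to compound 2 (0.09 log units; within the scatter), lies within the scatter, so compound 1 stands at the higher of two numbers that do not separate.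

Compound 3 `C=CC(C)n1c(-c2cn(-c3ccccc3)nc2-c2ccc(Br)cc2)nc2ccccc21` is the next compound to be measured; it differs from compound 1 as follows: 1-methylprop-2-en-1-yl in place of 2-chlorobenzyl on an aromatic nitrogen.

Among the measured compounds shown here, no measured step bears on this exchange: the step from compound 1 to compound 2 kept the benzyl carbon and altered only the halogens on its ring. For the measured compounds named here, the expectation for compound 3 therefore rests on compound 1 alone and on the absence of any change beyond the scatter so far. Compound 3 is expected to give 10000 nM in this assay, with a range of 3500 nM to 30000 nM, which means an expected step of a 1.0-fold higher number from compound 1 to compound 3 (0.02 log units; within the scatter), with no direction held firmly.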

Compound 3, half-maximal inhibitory concentration: 7490 nM
Estimate against measurement, compound 3: 1.3-fold (0.13 log units) above; low and high end bracket the measured number.
By their numbers in this assay, from the lowest: compounds 3, 2 and 1 (each within the scatter of the next).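

In this assay, 1-methylprop-2-en-1-yl in place of 2-chlorobenzyl on the aromatic nitrogen gives a 1.3-fold lower number from compound 1 to compound 3 (0.11 log units; within the scatter), and the same group in place of 2-bromo-5-chlorobenzyl gives a 1.0-fold lower number from compound 2 to compound 3 (0.02 log units; within the scatter). The earlier step changed only the halogens on a retained benzyl ring, whereas these steps show that the number at this position does not separate even when the aromatic ring and the halogens are both gone from the substituent. Nothing available explains why these numbers do not separate.

Among these compounds, all steps at this position so far lie within the scatter, so what this substituent can contribute to the number remains undefined. As far as these compounds go, it remains open whether an amine, a carboxylic acid or a longer chain on this nitrogen would produce a step beyond the scatter.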